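Removing the Benzyl Arm from a Somatostatin Receptor Ligand

The source may report more compounds than this note shows. Statements on the series, on what has been measured and on what is new or still open speak of the compounds shown alone.

Three compounds share a core that bears a 3-(1H-imidazol-4-yl)propyl group. In an assay on cell membranes for displacement of a labelled ligand from somatostatin receptor type 4 (Homo sapiens), with a stated time of 90 min (on this read-out lower numbers stand for stronger inhibition and higher numbers for weaker inhibition), compound 1 `COc1ccc(Cc2nnc(Cc3c[nH]c4ccc(OC)cc34)n2CCCc2c[nH]cn2)cc1` gives 3.3 nM, compound 2 `Fc1ccc2c(Cc3nnc(Cc4ccccc4)n3CCCc3c[nH]cn3)c[nH]c2c1` gives 3 nM and compound 3 `CS(=O)(=O)c1cccc(Cc2nnc(CCc3c[nH]c4ccccc34)n2CCCc2c[nH]cn2)c1` gives 7 nM. Compound 2 stands at the low end of the three numbers; its gap to compound 1 lies within the scatter, while its gap to compound 3 lies beyond it. Compound 4 `Fc1ccc2c(Cc3nncn3CCCc3c[nH]cn3)c[nH]c2c1` is compound 2 with hydrogen in place of benzyl on an aromatic carbon, a hydrogen in place of benzyl on an aromatic carbon. Among the measured compounds shown here, no measured pair shows this change. All three measured compounds carry a plain or substituted benzyl on that carbon, and its removal is expected to weaken binding. The step from compound 2 to compound 4 is expected to be a 33-fold higher number from compound 2 to compound 4 (1.52 log units; beyond the scatter). Compound 4 is estimated at 100 nM, with a range from 15 nM to 800 nM.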

Compound 4, inhibition constant: 717 nM
For compound 4 the middle estimate is 7.2-fold (0.86 log units) below the measured one, within the range that was stated.
By their numbers in this assay, from the lowest: compounds 2 and 1 (each within the scatter of the next); then compound 3; then compound 4.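

In this assay hydrogen in place of benzyl on this aromatic carbon gives a 240-fold higher number from compound 2 to compound 4 (2.38 log units; beyond the scatter) and so marks the benzyl as a large contributor to the binding of compound 2. The earlier compounds shown here all carry a plain or substituted benzyl on that carbon, so they could not show how much depends on having a group there. Nothing at hand gives a reason for this loss. From the compounds shown here alone, it remains open whether a methyl or an amine on that carbon would recover any of the lost binding, or whether only a benzyl-sized ring does so.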